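Side-Chain Amine Variation and Cytotoxicity Toward L02 Cells

This account rests on a few compounds, and the source may have more. Where it says the series, first, only, none or still open, it means among the compounds named here.

Compound 1 `O=C1c2c[n+]([O-])c3ccccc3c2C(=O)c2c1c1ccccc1n2CCCCN1CCCCC1`: 610 nM
Compound 2 `O=C1c2c[n+]([O-])c3ccccc3c2C(=O)c2c1c1ccccc1n2CCCCN1CCNCC1`: 1380 nM
Compound 3 `O=C1c2c[n+]([O-])c3ccccc3c2C(=O)c2c1c1ccccc1n2CCN1CCCC1`: 930 nM

In a toxicity assay on L02 cells (Homo sapiens) for cytotoxicity, read by MTT assay, with a stated time of 72 h (a higher number here means a weaker inhibitor, a lower number a stronger inhibitor), compound 3 stands second highest of the three numbers, within the scatter of both compound 1 and compound 2. Compound 4 `CCCN1CCN(CCCCn2c3c(c4ccccc42)C(=O)c2c[n+]([O-])c4ccccc4c2C3=O)CC1` differs from compound 3 by 2-(4-propylpiperazin-1-yl)ethyl in place of pyrrolidin-1-yl on a saturated chain carbon, two bonds along the chain from an aromatic nitrogen. The relevant measured steps are a 1.5-fold higher number from compound 1 to compound 3 (0.18 log units; within the scatter) and a 1.5-fold lower number from compound 2 to compound 3 (0.17 log units; within the scatter), both within the scatter, and a 2.3-fold higher number from compound 1 to compound 2 (0.35 log units; beyond the scatter), a modest shift beyond the scatter for a piperazine in place of a piperidine. Since compound 4 carries a substituted piperazine on the longer chain, a small rise toward the value of compound 2 is expected, giving an estimated 1.2-fold higher number from compound 3 to compound 4 (0.07 log units; within the scatter). Compound 4 is therefore expected to give about 1100 nM, within a range of 550 nM to 2200 nM.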

Compound 4, half-maximal inhibitory concentration: 6830 nM
Compound 4: middle estimate off by 6.2-fold (0.79 log units), on the low side; measured number outside the range, above it.
By their numbers in this assay, from the lowest: compounds 1, 3 and 2 (each within the scatter of the next, the first and the last beyond it); then compound 4.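

In this assay the largest earlier step was a 2.3-fold higher number from compound 1 to compound 2 (0.35 log units; beyond the scatter) and came from exchanging one ring amine for another, whereas propyl in place of hydrogen on the amine nitrogen in the ring gives a 4.9-fold higher number from compound 2 to compound 4 (0.69 log units; beyond the scatter) on its own. Compound 4 also stands clear of the other two, with an 11-fold higher number from compound 1 to compound 4 (1.05 log units; beyond the scatter) and a 7.3-fold higher number from compound 3 to compound 4 (0.87 log units; beyond the scatter) in this series, so substitution on that ring nitrogen marks it off from every earlier compound. Nothing available accounts for this rise. On these data alone, it remains open whether methyl on that ring nitrogen, or a longer chain such as butyl, would place a compound nearer compound 2 or compound 4.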